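A few compounds are considered here, and "the series" means these few. Any claim that something is new, unique, unknown or untested is made for them only; others in the source may bear on it.

Compound 1 `O=C1CCCCC/C1=C\c1ccccc1` gives 110000 nM in a functional assay on CCRF-CEM cells (Homo sapiens) for inhibition; on this read-out higher numbers stand for weaker inhibition and lower numbers for stronger inhibition. Two close relatives each carry one extra group on the aromatic ring: compound 2 `O=C1CCCCC/C1=C\c1cccc(F)c1`, with fluoro, gives 224000 nM, and compound 3 `Cc1cccc(/C=C2\CCCCCC2=O)c1`, with methyl, gives 170000 nM. Compound 1 therefore stands close to both. There is a 1.5-fold higher number from compound 1 to compound 3 (0.19 log units; within the scatter), which lies within the scatter, and a 2.0-fold higher number from compound 1 to compound 2 (0.31 log units; beyond the scatter), which lies just beyond it and is modest.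

Compound 4 `Cc1ccc(/C=C2\CCCCCC2=O)cc1` has not yet been measured. Its difference from compound 1 is methyl in place of hydrogen on an aromatic carbon, para to a group of 9 heavy atoms.

The most relevant precedent is compound 3, which makes the same swap of hydrogen for methyl on a different aromatic carbon and shows a 1.5-fold higher number from compound 1 to compound 3 (0.19 log units; within the scatter). The fluoro swap in compound 2 is a less direct guide, though its a 2.0-fold higher number from compound 1 to compound 2 (0.31 log units; beyond the scatter) points the same way. Between these two relatives there is a 1.3-fold lower number from compound 2 to compound 3 (0.12 log units; within the scatter), again within the scatter. Among the measured compounds shown here, a small move toward a higher number in this assay is therefore expected, with no step clearly beyond the scatter. The expected change is a 1.5-fold higher number from compound 1 to compound 4 (0.16 log units; within the scatter). Compound 4 is estimated at 160000 nM, with an expected range from 90000 nM to 280000 nM.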

Compound 4, half-maximal inhibitory concentration: > 500000 nM
Compound 4: only a limit was reported; the forecaster's own chance of this, stated with the estimate: 5%; middle value at least 3.1-fold (0.49 log units) away from the limit.
By their numbers in this assay, from the lowest: compounds 1, 3 and 2 (each within the scatter of the next, the first and the last beyond it). At a limit, above all of these: compound 4.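

Placing a methyl on an aromatic carbon, para to a group of 9 heavy atoms, gives an at least 4.5-fold higher number from compound 1 to compound 4 (0.65 log units; beyond the scatter), so in this assay this position responds to a small change in a way that the earlier compounds did not reveal. The same swap of hydrogen for methyl on a different aromatic carbon gives only a 1.5-fold higher number from compound 1 to compound 3 (0.19 log units; within the scatter), which means that, for this pair of methyl compounds, where the group sits on the ring matters more than its mere presence. Compound 4 is reported only as a limit, so the full size of its step stays unknown: the limit of > 500000 nM in this assay, at which 1 of the 4 values shown sits.

Among the compounds shown, methyl is the only group at this position, so it remains open whether a smaller fluoro, a longer chain such as ethyl, an amine or a carboxylic acid placed there would also push the number up, or whether some group would bring it back toward that of compound 1. It also remains open whether any change on this ring could bring the number lower than that of compound 1, since no compound shown does so beyond the scatter.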